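Swapping a Cyclohexylamine Tail for a Naphthyl Ether

The source may report more compounds than this note shows. Statements on the series, on what has been measured and on what is new or still open speak of the compounds shown alone.

Compound 3 `CC(C)C[C@H](N)c1cc(C(F)(F)F)ccc1N1CCN(C(=O)CCNC2CCCCC2)CC1` gives 4800 nM in an assay on HEK293 cells for displacement of a labelled ligand from Melanocortin receptor 4 (Homo sapiens) (on this read-out lower numbers stand for stronger inhibition and higher numbers for weaker inhibition), the highest of the two numbers available. Compound 1 `CC(C)C[C@H](N)c1cc(C(F)(F)F)ccc1N1CCN(C(=O)COc2ccc3ccccc3c2)CC1` gives 2000 nM in this assay. Compound 2 `CC(C)C[C@H](N)c1cc(C(F)(F)F)ccc1N1CCN(C(=O)CCC(N)=O)CC1` reaches only the limit > 10000 nM in this assay, which is a limit rather than a number. Compound 4 `CC(C)C[C@H](N)c1cc(C(F)(F)F)ccc1N1CCN(C(=O)COc2cccc3ccccc23)CC1` has not yet been measured; it differs from compound 3 in one place: (naphthalen-1-yl)oxy in place of (cyclohexylamino)methyl on a saturated chain carbon bound to a carbonyl carbon.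

The measured step that bears most directly on this change runs the opposite way, a 2.4-fold higher number from compound 1 to compound 3 (0.38 log units; beyond the scatter), where (naphthalen-2-yl)oxy gave way to (cyclohexylamino)methyl on a saturated chain carbon bound to a carbonyl carbon. Among the measured compounds shown here, compound 4 undoes that exchange, but with (naphthalen-1-yl)oxy instead; whether this group behaves like the (naphthalen-2-yl)oxy group of compound 1 cannot be read from the three compounds measured so far. A fall in the number of roughly the size of that earlier step is therefore expected, a 2.2-fold lower number from compound 3 to compound 4 (0.34 log units; beyond the scatter). Compound 4 is estimated at 2200 nM, within 700 nM to 7000 nM.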

Compound 4, inhibition constant: 2600 nM
For compound 4 the middle estimate is 1.2-fold (0.07 log units) below the measured one; the range from low to high includes it.
By their numbers in this assay, from the lowest: compounds 1, 4 and 3 (each within the scatter of the next, the first and the last beyond it). At a limit, above all of these: compound 2.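

In this assay, naphthalen-1-yl in place of naphthalen-2-yl on the ether oxygen gives a 1.3-fold higher number from compound 1 to compound 4 (0.11 log units; within the scatter), so the two naphthyl ethers cannot be told apart here. (Naphthalen-1-yl)oxy in place of (cyclohexylamino)methyl gives a 1.8-fold lower number from compound 3 to compound 4 (0.27 log units; within the scatter), while in place of carbamoylmethyl it gives an at least 3.8-fold lower number from compound 2 to compound 4 (0.58 log units; beyond the scatter), so among these two exchanges only the one from carbamoylmethyl lies clearly beyond the scatter. Compound 2 stays at a limit of the assay, not a number: the limit of > 10000 nM in this assay, at which 1 of the 4 values shown sits.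

Going by these compounds, whether a single benzene ring, as in a phenoxy group, would serve as well as the naphthyl ethers remains open. So does the effect of a carboxylic acid or a longer chain at this position on the saturated chain carbon bound to the carbonyl carbon.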